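From 3-bromophenyl to 4-bromophenyl: a cytotoxicity estimate

A few compounds are considered here, and "the series" means these few. Any claim that something is new, unique, unknown or untested is made for them only; others in the source may bear on it.

In an ADME assay on V79 cells (Cricetulus griseus) for cytotoxicity, read by MTT assay, with a stated time of 72 h (a higher number here means a weaker inhibitor, a lower number a stronger inhibitor), compound 3 `COc1ccc(Nc2nnnn2-c2cccc(Br)c2)cc1` gives 124000 nM. Two relatives set the context: compound 1 `COc1ccc(Nc2nnnn2-c2ccccc2F)cc1` gives 212000 nM, and compound 2 `COc1ccc(-n2nnnc2Nc2ccc(Cl)cc2)cc1` gives 245000 nM. Compound 3 sits within the usual scatter of both, so these three numbers cannot be ranked with any confidence.

The next compound is compound 4 `COc1ccc(Nc2nnnn2-c2ccc(Br)cc2)cc1`, which keeps the same atoms but joins them differently, with 4-bromophenyl in place of 3-bromophenyl on an aromatic nitrogen.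

Within the data shown here, only one measured step bears on this change. Placing 3-bromophenyl where 2-fluorophenyl had stood on that nitrogen gave a 1.7-fold lower number from compound 1 to compound 3 (0.23 log units; within the scatter). That swap altered both the halogen and its ring position, yet the result stayed within the scatter. Among the measured compounds shown here, no measured pair isolates the position of the bromine alone, so the evidence here is indirect. Since even that larger change produced no clear shift, no step beyond the scatter is expected in this assay, in either direction.

The expected step is a 1.2-fold higher number from compound 3 to compound 4 (0.08 log units; within the scatter). For compound 4 the estimated value is 150000 nM, with an expected range from 80000 nM to 280000 nM.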

Compound 4, half-maximal inhibitory concentration: 125000 nM
For compound 4 the middle estimate is 1.2-fold (0.08 log units) above the measured one, within the range that was stated.
By their numbers in this assay, from the lowest: compounds 3, 4, 1 and 2 (each within the scatter of the next).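

Among these compounds, exchanging 3-bromophenyl for 4-bromophenyl isolates where the bromine sits on this ring, which the earlier compounds could not do, and in this assay the result is a 1.0-fold higher number from compound 3 to compound 4 (0.00 log units; within the scatter). Within this assay, then, these two placements of the bromine cannot be told apart. Starting from 2-fluorophenyl, the 4-bromophenyl group gives a 1.7-fold lower number from compound 1 to compound 4 (0.23 log units; within the scatter), so neither bromophenyl group stands clear of the 2-fluorophenyl group, and no measurement shown here offers an explanation for how closely these numbers agree.

Still open is whether a group of a different kind on this ring, such as an amine or a carboxylic acid in place of the bromine, would give a number beyond the scatter of these compounds. Going by these compounds, it is also open whether a longer chain between the ring and the shared core would move the number clearly, since every change compared so far swaps one halogen-bearing phenyl group for another on the same aromatic nitrogen.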